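From 4-methylphenyl to 2-methylphenyl: a shifted methyl group

A few compounds are considered here, and "the series" means these few. Any claim that something is new, unique, unknown or untested is made for them only; others in the source may bear on it.

Among the compounds with values here, in a functional assay on ileum (Cavia porcellus) for antagonist activity (on this read-out lower numbers stand for stronger inhibition and higher numbers for weaker inhibition), compound 3 (`Cc1ccc(OCCCOc2ccc3c(O)c([N+](=O)[O-])c(=O)oc3c2)cc1`) gives 4500 nM, the only actual number among the measured compounds. Compound 1 (`COC(=O)c1ccc(OCCCOc2ccc3c(O)c([N+](=O)[O-])c(=O)oc3c2)cc1`) reads > 10000 nM, which is a limit of the assay. Compound 2 (`N#Cc1ccc(OCCCOc2ccc3c(O)c([N+](=O)[O-])c(=O)oc3c2)cc1`) reads > 10000 nM, which is also a limit.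

Compound 4 (`Cc1ccccc1OCCCOc1ccc2c(O)c([N+](=O)[O-])c(=O)oc2c1`) has the same atoms as compound 3, joined differently, with 2-methylphenyl in place of 4-methylphenyl on an oxygen on a saturated carbon.

Within the data shown here, two measured steps bear on this change only loosely: an at least 2.2-fold lower number from compound 1 to compound 3 (0.34 log units; beyond the scatter) and an at least 2.2-fold lower number from compound 2 to compound 3 (0.34 log units; beyond the scatter). Each puts methyl in place of another group on an aromatic carbon, and neither moves the methyl, so they set no size for this change. The closest guide is compound 3 at 4500 nM, and no step beyond the scatter is expected in this assay, in either direction. The expected change is a 1.1-fold higher number from compound 3 to compound 4 (0.05 log units; within the scatter). Compound 4 is estimated at 5000 nM, with an expected range of 1800 nM to 10000 nM.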

Compound 4, half-maximal inhibitory concentration: 590 nM
The estimate for compound 4 lay 8.5-fold (0.93 log units) above the measured number; measured number below the stated range.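

In this assay, moving the methyl group alone, from 4-methylphenyl to 2-methylphenyl, gives a 7.6-fold lower number from compound 3 to compound 4 (0.88 log units; beyond the scatter), beyond the scatter. Within the data shown here, this shows that the place of the methyl on this ring changes the read-out even with the same atoms, whereas the earlier compounds differed only in which group they carried, never in where it sat. The 2-methylphenyl group also gives an at least 16-fold lower number from compound 2 to compound 4 (1.22 log units; beyond the scatter) and an at least 16-fold lower number from compound 1 to compound 4 (1.22 log units; beyond the scatter), but these two steps give only a minimum size, as they start from a limit of the assay: the limit of > 10000 nM in this assay, at which 2 of the 4 values shown sit.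

On these data alone, whether the same shift would help with another group remains open, for instance a chlorine or a methoxy group in place of the methyl of 2-methylphenyl. As far as these compounds go, it is also open how 2-methylphenyl would read on a longer chain.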